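From pyridin-2-yl to pyridin-3-yl on a shared core

The source may report more compounds than this note shows. Statements on the series, on what has been measured and on what is new or still open speak of the compounds shown alone.

Measured so far in an ADME assay (liver) for metabolic stability, with Liver microsome (Homo sapiens) as the target, using microsomes; a lower number here means slower removal, a higher number faster removal of the compound:
Compound 1 `Fc1cccc(CNc2nnc(-c3c[nH]c4ncccc34)o2)c1`: 54 mL.min-1.g-1
Compound 2 `c1ccc(CNc2nnc(-c3c[nH]c4ncccc34)o2)nc1`: < 14 mL.min-1.g-1, a limit and not a number

Compound 2 has no exact value, only a limit, and this is the limit of < 14 mL.min-1.g-1 in this assay, at which 1 of the 2 values shown sits. Within the data shown here, its single measured step, an at least 3.8-fold lower number from compound 1 to compound 2 (0.58 log units; beyond the scatter), lies beyond the scatter. That step put pyridin-2-yl in place of 3-fluorophenyl on a saturated chain carbon bound to a nitrogen on an aromatic ring.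

Compound 3 `c1cncc(CNc2nnc(-c3c[nH]c4ncccc34)o2)c1` has the same atoms as compound 2, joined differently: pyridin-3-yl in place of pyridin-2-yl on a saturated chain carbon bound to a nitrogen on an aromatic ring. In words, pyridin-3-yl takes the place of pyridin-2-yl at that same carbon.

Among the measured compounds shown here, no measured step compares these two groups directly. The step of an at least 3.8-fold lower number from compound 1 to compound 2 (0.58 log units; beyond the scatter) shows only what one pyridinyl group did in place of 3-fluorophenyl. Compound 3 also carries a pyridinyl group, so it is expected to stay closer to compound 2 than to compound 1, perhaps drifting slightly upward in this assay. The expected change is small, an at least 1.1-fold higher number from compound 2 to compound 3 (0.05 log units; that floor lies within the scatter). The estimated value for compound 3 is 16 mL.min-1.g-1, with an expected range of 8 mL.min-1.g-1 to 35 mL.min-1.g-1.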

Compound 3, intrinsic clearance in microsomes: < 14 mL.min-1.g-1
Compound 3: a limit, no number; the forecaster's own chance of this, stated with the estimate: 45%; at least 1.1-fold (0.05 log units) between middle value and limit.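

In this assay, replacing 3-fluorophenyl with pyridin-3-yl gives an at least 3.8-fold lower number from compound 1 to compound 3 (0.58 log units; beyond the scatter), so the lower number is no longer tied to pyridin-2-yl alone: two pyridinyl groups on the shared core now both show it against compound 1. The step from compound 2 to compound 3 cannot be read, as each of these compounds carries a limit of the assay and not a number, and nothing shows whether swapping pyridin-2-yl for pyridin-3-yl changes removal at all. The two pyridinyl compounds therefore sit together at the edge of what this assay can report: the limit of < 14 mL.min-1.g-1 in this assay, at which 2 of the 3 values shown sit.

Going by these compounds, how far each of them lies past that limit stays unknown, so the two pyridinyl groups cannot be placed in order. On these data alone, it also remains open whether pyridin-4-yl, a pyrimidinyl ring or a longer chain carrying the pyridin-3-yl group would keep the number as low in this assay.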